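Clearance notes: triazolyl to pyrazolyl swap on the aryl

This account rests on a few compounds, and the source may have more. Where it says the series, first, only, none or still open, it means among the compounds named here.

Measured so far:
compound 1 `COc1cc(N2CCN(C(=O)N[C@@H](C)c3cccc4ccccc34)CC2)ccc1-n1cc(C)nn1` — 230 mL.min-1.g-1
compound 2 `COc1cc(C2CCN(C(=O)N[C@@H](C)c3cccc4ccccc34)CC2)ccc1-c1cnc(C)o1` — 170 mL.min-1.g-1

In an ADME assay on microsomes from liver (Rattus norvegicus) for metabolic stability, read by LC-MS (on this read-out lower numbers stand for slow clearance and higher numbers for fast clearance), compound 1 gives 230 mL.min-1.g-1, the higher of the two numbers in hand. Going by the values given here, compound 2 gives 170 mL.min-1.g-1 in this assay; the gap between the two compounds lies within the scatter, so nothing can be read from it, and compound 2 differs from compound 1 at more than one place, so it offers no single step to lean on.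

Compound 3 `COc1cc(N2CCN(C(=O)N[C@@H](C)c3cccc4ccccc34)CC2)ccc1-c1cnn(C)c1` differs from compound 1 in one place only: 1-methyl-1H-pyrazol-4-yl in place of 4-methyl-1H-1,2,3-triazol-1-yl on an aromatic carbon. Among the compounds with values here, no measured pair of this kind is available. The two groups are aromatic five-membered rings of equal size, both without hydrogen-bond donors, sitting at the same place, ortho to a methoxy group and para to a large group. On that basis no step beyond the scatter is expected in this assay, in either direction; the expected step is no change at the digits printed from compound 1 to compound 3 (within the scatter). For compound 3 the estimate in this assay is 230 mL.min-1.g-1, with a range from 120 mL.min-1.g-1 to 450 mL.min-1.g-1.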

Compound 3, intrinsic clearance in microsomes: 150 mL.min-1.g-1
The estimate for compound 3 lay 1.5-fold (0.19 log units) above the measured number, and the stated range covers the measured number.
By their numbers in this assay, from the lowest: compounds 3, 2 and 1 (each within the scatter of the next).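

Going by these compounds alone, the exchange of 4-methyl-1H-1,2,3-triazol-1-yl for 1-methyl-1H-pyrazol-4-yl gives the first single-place comparison, and in this assay it reads as a 1.5-fold lower number from compound 1 to compound 3 (0.19 log units; within the scatter). At this position, ortho to a methoxy group and para to a large group, this read-out therefore does not separate a five-membered aromatic ring with 3 hetero atoms from one with 2 hetero atoms, at least for this pair of methylated rings. No measurement bears on what lies behind this result.

Whether any group at this position can give a step beyond the scatter stays open, since the compounds shown carry only methylated five-membered aromatic rings there and nothing such as a carboxylic acid, a dimethylamino group or a morpholine ring. Compound 2 differs from both compound 1 and compound 3 at more than one place, so the compounds shown also give no single step at any other part of the molecule, and how much clearance in this assay depends on the rest of the shared core remains unknown.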